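The source may hold more compounds than are shown below. What is called first, only, known or untested is meant among the compounds shown, and "the series" means these compounds.

The compounds measured in an assay on isolated protein for inhibition of cytosolic endo-beta-N-acetylglucosaminidase (Homo sapiens), tested at 1000 uM (a higher number here means more inhibition at the concentration tested (going by the name of the read-out), a lower number less inhibition), are these:

Compound 1, `O=C(O)[C@H]1NC[C@@H](O)[C@H](O)[C@H]1O`, gives 6.3% in this assay.

Compound 2, `O=C(O)[C@H]1NC[C@H](O)[C@@H](O)[C@H]1O`, gives 2.6% in this assay.

Both are sugar-like ring acids carrying three hydroxyl groups, and they are built from the same atoms and bonds. Compound 2 sits alongside compound 1: the change a number 3.7 percentage points lower from compound 1 to compound 2 (within the scatter), so the two numbers cannot be told apart. Going by the values given here, that pair is the only step measured, and it rests on (the fact that compounds 1 and 2 differ only in the configuration as drawn).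

Compound 3, `O=C(O)[C@@H]1NC[C@H](O)[C@@H](O)[C@H]1O`, has not yet been measured. It differs from compound 2 as follows: the two compounds have the same atoms and bonds and differ only in configuration as drawn: 1 of 4 stereo elements differ; a stereocentre at a saturated ring carbon is drawn S in compound 2 and R in compound 3. So the only kind of change seen so far, a swap of ring configuration, is again the kind of change made here, though now at a single centre rather than two. Since swapping two centres in going from compound 1 to compound 2 moved the number by an amount within the scatter, a single swap is expected to do no more, and compound 3 is estimated to show a step of a number 1.4 percentage points higher from compound 2 to compound 3 (within the scatter) in this assay. Compound 3 is therefore expected to give about 4%, with a range from 0% to 14%.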

Compound 3, a percentage reported as inhibition, at one concentration (the size of the read-out at that concentration, not a potency): 42%
Estimate against measurement, compound 3: 38 percentage points below, and the stated range ends below it.
By their numbers in this assay, from the lowest: compounds 2 and 1 (each within the scatter of the next); then compound 3.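

In this assay, inverting one stereocentre at a saturated ring carbon gives a number 39.4 percentage points higher from compound 2 to compound 3 (beyond the scatter), so a single centre can separate two numbers clearly, which the earlier pair of compounds gave no sign of. Changing more centres does not by itself mean a larger step: three differ in a number 35.7 percentage points higher from compound 1 to compound 3 (beyond the scatter), a step of similar size, whereas the two that differ between compound 1 and compound 2 left numbers that cannot be told apart. The rise can be tied to configuration alone, because no atom or bond changes between the two compounds: the fact that compounds 2 and 3 differ only in the configuration as drawn

The compounds shown leave open whether this one centre is enough on its own or works only together with the configuration of the other ring carbons, since compound 3 is the only compound here that gives a high number. They also leave open what happens when the carboxylic acid is replaced by an amide or a hydroxymethyl group, and how potent compound 3 is, as 42% is a reading at one concentration and not a potency.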